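The source may report more compounds than this note shows. Statements on the series, on what has been measured and on what is new or still open speak of the compounds shown alone.

Of the compounds shown here, three have been measured in a functional assay on SK-N-AS cells (Homo sapiens) for antiproliferative activity, with a stated time of 72 h (a higher number here means a weaker inhibitor, a lower number a stronger inhibitor), so far. Compound 1 (`Cc1ccc(NC(=O)CCN(Cc2ccc(C(=O)NO)cc2)C(=O)c2cc(C)cc(C)c2)cc1`) gives 220 nM and compound 2 (`Cc1ccc(CNC(=O)CCN(Cc2ccc(C(=O)NO)cc2)C(=O)c2ccc(N(C)C)cc2)cc1`) gives 340 nM as the second highest of the three numbers, within the scatter of compound 1. Compound 3 (`COc1cc(OC)cc(C(=O)N(CCC(=O)NCc2ccccc2)Cc2ccc(C(=O)NO)cc2)c1`) reads much higher at 9470 nM in the same test. Compound 4 (`CN(C)c1ccc(C(=O)N(CCC(=O)NCc2ccc(Cl)cc2)Cc2ccc(C(=O)NO)cc2)cc1`) departs from compound 2 at one place, 4-methylbenzyl becoming 4-chlorobenzyl: chloro in place of methyl on an aromatic carbon with chloro in place of methyl on an aromatic carbon, para to a large group. For the measured compounds named here, no measured pair shows this change, so no shift beyond the scatter is expected in this assay here. The estimated step of a 1.1-fold lower number from compound 2 to compound 4 (0.05 log units; within the scatter) is small. For compound 4 the expected value is 300 nM with an estimated range from 110 nM to 800 nM in this test.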

Compound 4, half-maximal inhibitory concentration: 390 nM
Compound 4: the middle estimate sits 1.3-fold (0.11 log units) below what was measured; the range from low to high includes it.
By their numbers in this assay, from the lowest: compounds 1, 2 and 4 (each within the scatter of the next); then compound 3.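

Chloro in place of methyl on an aromatic carbon, para to a large group, gives the first single-place comparison in this assay, with a 1.1-fold higher number from compound 2 to compound 4 (0.06 log units; within the scatter). The two compounds therefore cannot be told apart in this test, so this one swap between 4-methylbenzyl and 4-chlorobenzyl leaves no readable mark on the number. No measured property is available to account for this result. The compounds shown leave open whether an amine or a carboxylic acid at this place would read differently. They also leave open whether chloro and methyl would stay level with the other amide groups of the series.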